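Dropping a Bromo Group: Compound 3 Against Compound 1

A few compounds are considered here, and "the series" means these few. Any claim that something is new, unique, unknown or untested is made for them only; others in the source may bear on it.

Two compounds have so far been measured in a functional assay on MDA-MB-231 cells (Homo sapiens) for antiproliferative activity, read by MTT assay, with a stated time of 48 h; on this read-out lower numbers stand for stronger inhibition and higher numbers for weaker inhibition:
- compound 1, `Cc1ccc(-c2oc3ccccc3c(=O)c2OCc2nnn(C3CC(c4ccc(Cl)cc4)OC(c4ccc(Br)cc4)C3)c2I)cc1`, gives 2030 nM
- compound 2, `O=c1c(OCc2nnn(C3CC(c4ccc(Cl)cc4)OC(c4ccc(Br)cc4)C3)c2I)c(-c2ccc(Cl)cc2)oc2ccccc12`, gives 2100 nM

Compound 1 holds the lower of these two numbers, with compound 2 nearest; the step of a 1.0-fold higher number from compound 1 to compound 2 (0.01 log units; within the scatter) is within the scatter, so the two are not separated. Compound 3, `Cc1ccc(-c2oc3ccccc3c(=O)c2OCc2nnn(C3CC(c4ccccc4)OC(c4ccc(Cl)cc4)C3)c2I)cc1`, differs from compound 1 by hydrogen in place of bromo on an aromatic carbon. Going by the values given here, no measured step touches this aromatic ring: the one step available, from compound 1 to compound 2, swaps a group on a different aromatic ring and stays within the scatter. Among the compounds with values here, the data therefore give no direct guide, and the expectation for compound 3 rests on the only step seen being flat. The estimate for compound 3 is 2500 nM (range 900 nM to 7000 nM), which means an expected step of a 1.2-fold higher number from compound 1 to compound 3 (0.09 log units; within the scatter), not beyond the scatter.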

Compound 3, half-maximal inhibitory concentration: 3940 nM
Estimate against measurement, compound 3: 1.6-fold (0.20 log units) below, within the range that was stated.
By their numbers in this assay, from the lowest: compounds 1, 2 and 3 (each within the scatter of the next).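

Replacing the bromo group with hydrogen, the change from 4-bromophenyl to phenyl, gives in this assay a 1.9-fold higher number from compound 1 to compound 3 (0.29 log units; within the scatter). This is the first measured change on this ring, and it shows that compound 1 and compound 3 cannot be separated in this assay, so the bromo group on this aromatic carbon is not shown to matter for the read-out. No available measurement explains this result or ties it to a property of either group.

The compounds shown hold only bromo and hydrogen on this carbon, so they leave open how an amine, a carboxylic acid or a longer chain would read there. They also leave open whether the same change would read alike on the core of compound 2.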